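From Isobutyl to tert-Butyl on the Shared Core

The source may hold more compounds than are shown below. What is called first, only, known or untested is meant among the compounds shown, and "the series" means these compounds.

- Compound 1 `COc1ccc(-c2[nH]c3ccc(C(C)C)cc3c2C=O)cc1`: 29 nM
- Compound 2 `COc1ccc(-c2[nH]c3ccc(CC(C)C)cc3c2C=O)cc1`: 72 nM
- Compound 3 `COc1ccc(-c2[nH]c3ccc(C(C)(C)C)cc3c2C=O)cc1`: not yet measured

In a functional assay on MDA-MB-231 cells (Homo sapiens) for antiproliferative activity, with a stated time of 4 days (on this read-out higher numbers stand for weaker inhibition and lower numbers for stronger inhibition), compound 2 has the higher of the two measured numbers, at 72 nM. Compound 3 differs from it by one change, tert-butyl in place of isobutyl on an aromatic carbon. Among the compounds with values here, only one measured step bears on this swap, a 2.5-fold higher number from compound 1 to compound 2 (0.39 log units; beyond the scatter), a modest step between two other alkyl groups at that carbon. Within the data shown here, no compound with tert-butyl has been measured, so the guidance is thin. Taking compound 1 at 29 nM as the nearer structural match, a small move towards a lower number is expected, possibly not beyond the scatter. The expected change is a 1.8-fold lower number from compound 2 to compound 3 (0.26 log units; within the scatter). For compound 3 the estimate is 40 nM, with an expected range of 14 nM to 115 nM.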

Compound 3, half-maximal inhibitory concentration: 280 nM
Estimate against measurement, compound 3: 7.0-fold (0.85 log units) below; measured number outside the range, above it.
By their numbers in this assay, from the lowest: compound 1; then compound 2; then compound 3.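

In this assay, the exchange of isobutyl for tert-butyl keeps the same four carbons and only joins them differently, yet it gives a 3.9-fold higher number from compound 2 to compound 3 (0.59 log units; beyond the scatter) and so leaves compound 3 with the highest number of the three. Adding one methyl to the isopropyl group gives a larger step, a 9.7-fold higher number from compound 1 to compound 3 (0.98 log units; beyond the scatter), which shows that the result at this aromatic carbon depends on how the carbons are arranged and not on their count alone. No measurement shown here accounts for this difference.

On these data alone, it remains open whether a smaller group such as methyl or ethyl would give a number lower than or close to that of compound 1. As far as these compounds go, the effect at this carbon of a longer chain such as n-butyl, a cyclopropyl ring or an amine also remains unknown.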